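The source may hold more compounds than are shown below. What is called first, only, known or untested is meant among the compounds shown, and "the series" means these compounds.

The measured compounds and their values in an ADME assay on MT4 cells (Homo sapiens) for cytotoxicity, read by MTT assay; a higher number here means that more compound is tolerated, a lower number that less compound is tolerated:

Compound 1, `O=C(CSc1nnnn1-c1cccc2ccccc12)N/N=C/c1cccc(Cl)c1`: 240000 nM
Compound 2, `O=C(CSc1nnnn1-c1cccc2ccccc12)N/N=C/c1ccc(F)cc1`: > 307000 nM

Compound 1 gives 240000 nM in this assay. For compound 2 the result in this assay is a limit of the assay, > 307000 nM. For the measured compounds named here, the only step between measured compounds is an at least 1.2-fold higher number from compound 1 to compound 2 (0.10 log units; that floor lies within the scatter), and the evidence on that step is the limit of > 307000 nM in this assay, at which 1 of the 2 values shown sits, so the floor of the step lies within the scatter and compound 2 stands at the upper edge of what the numbers show.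

Compound 3, `COc1ccc(/C=N/NC(=O)CSc2nnnn2-c2cccc3ccccc23)cc1`, differs from compound 2 by methoxy in place of fluoro on an aromatic carbon. Going by the values given here, no measured step in this assay touches a methoxy group, and the step from compound 1 to compound 2 concerns a different exchange at a different place on the same ring, so it bears on the present change only in showing that this ring tolerates a small substituent swap without a step beyond the scatter. The expected step is an at least 1.0-fold lower number from compound 2 to compound 3 (0.03 log units; that floor lies within the scatter), which is none beyond the scatter. Compound 3 is therefore expected to give 280000 nM in this assay, with a range from 140000 nM to 600000 nM.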

Compound 3, half-maximal cytotoxic concentration: > 298000 nM
Compound 3 was reported as a limit; the forecaster's own chance of this, stated with the estimate: 50%; middle value at least 1.0-fold (0.02 log units) from the limit.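

At the place para to a large group, methoxy now stands where fluoro stood, and in this assay this larger group also leaves the compound at a limit rather than at a measured number, so this position has now carried two different groups without a value falling inside the range of the assay: the limit of > 298000 nM in this assay, at which 1 of the 3 values shown sits. The step between compound 2 and compound 3 cannot be read, since both ends of it are limits, and the swap of fluoro for methoxy therefore has no measured size. For the compounds shown here, the one readable new step is an at least 1.2-fold higher number from compound 1 to compound 3 (0.09 log units; that floor lies within the scatter), and as its floor lies within the scatter, it does not separate the 4-methoxyphenyl compound from the 3-chlorophenyl compound.

Going by these compounds, how far compound 2 and compound 3 lie past their limits stays open, as does any order between them. Also open, on these data alone, is whether an amine or a carboxylic acid at this para place, or a longer chain such as ethoxy in place of methoxy, would bring the number down to a measured value in this assay.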